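Chain Length at the Ester and Growth Inhibition

A few compounds are considered here, and "the series" means these few. Any claim that something is new, unique, unknown or untested is made for them only; others in the source may bear on it.

The series rests on a shared core carrying a phenyl ester, and the three measured compounds differ only in the acyl chain. In a functional assay on A549 cells (Homo sapiens) for inhibition, with a stated time of 48 h, tested at 50 uM (a lower number here means less inhibition of growth, a higher number more inhibition of growth at the concentration tested), compound 1 `C=C[C@@](C)(/C=C/c1ccc(OC(C)=O)cc1)CCC=C(C)C` gives 72%. Compound 2 `C=C[C@@](C)(/C=C/c1ccc(OC(=O)CCC)cc1)CCC=C(C)C` differs by ethyl in place of hydrogen on a saturated chain carbon bound to a carbonyl carbon and in this assay gives 50%, so that a number 22 percentage points lower from compound 1 to compound 2 (beyond the scatter). Compound 3 `C=C[C@@](C)(/C=C/c1ccc(OC(=O)CCCCCCC)cc1)CCC=C(C)C` differs from compound 1 by hexyl in place of hydrogen on a saturated chain carbon bound to a carbonyl carbon. In this assay compound 3 gives 15%, and so a number 57 percentage points lower from compound 1 to compound 3 (beyond the scatter) and a number 35 percentage points lower from compound 2 to compound 3 (beyond the scatter). Within these three, compound 3 shows the least inhibition, and each lengthening of the chain has gone with a lower number.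

Compound 4 `C=C[C@@](C)(/C=C/c1ccc(OC(=O)CCCCCCCCC)cc1)CCC=C(C)C` has not been measured. It differs from compound 3 by ethyl in place of hydrogen on a saturated chain carbon, seven bonds along the chain from a carbonyl carbon, the same kind of change as from compound 1 to compound 2, though at a different place: there the ethyl enters on a carbon bound to a carbonyl carbon, here on a carbon seven bonds along the chain from a carbonyl carbon. Since compound 3 already stands at 15%, the expected step is smaller than the earlier one, a number 7 percentage points lower from compound 3 to compound 4 (within the scatter). The estimate for compound 4 in this assay is 8%, between 0% and 25%.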

Compound 4, percent growth inhibition at one concentration: 48%
Compound 4: the middle estimate sits 40 percentage points below what was measured, and the stated range ends below it.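

In this assay the lengthening of the acyl chain no longer goes with a lower number throughout, and compound 4 stands against that earlier pattern: there is a number 33 percentage points higher from compound 3 to compound 4 (beyond the scatter), alongside a number 2 percentage points lower from compound 2 to compound 4 (within the scatter) and a number 24 percentage points lower from compound 1 to compound 4 (beyond the scatter). Ethyl in place of hydrogen therefore does not carry a single outcome from one core to another in this series, and its direction reverses between the two places: the same change on two cores in this assay, a number 22 percentage points lower (beyond the scatter) from compound 1 to compound 2 and a number 33 percentage points higher (beyond the scatter) from compound 3 to compound 4, 55 percentage points apart, beyond the scatter of two such steps Hexyl in place of hydrogen does not carry over either, although these comparisons show only that the steps differ between cores, not why they differ or how such a change would behave on any further core: the same change on two cores in this assay, a number 57 percentage points lower (beyond the scatter) from compound 1 to compound 3 and a number 2 percentage points lower (within the scatter) from compound 2 to compound 4, 55 percentage points apart, beyond the scatter of two such steps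

The compounds shown leave open whether the number would keep rising, level off or fall again with a longer chain than that of compound 4. They also leave open how a branched acyl chain, or an amide in place of the ester, would fit into this series.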